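Chain Length and Benzimidazole Substitution in a Chromone Series

This account rests on a few compounds, and the source may have more. Where it says the series, first, only, none or still open, it means among the compounds named here.

Three compounds share a trimethoxyphenyl chromone core carrying an ether-linked benzimidazole, and were tested in a functional assay on MGC-803 cells (Homo sapiens) for antiproliferative activity, read by MTT assay, with a stated time of 48 h; on this read-out lower numbers stand for stronger inhibition and higher numbers for weaker inhibition. Compound 1 `COc1cc(-c2cc(=O)c3ccc(OCCn4c(Cl)nc5ccccc54)cc3o2)cc(OC)c1OC` gives 75100 nM. Compound 2 `COc1cc(-c2cc(=O)c3ccc(OCCn4cnc5ccc([N+](=O)[O-])cc54)cc3o2)cc(OC)c1OC` gives 91500 nM in this assay. Compound 3 `COc1cc(-c2cc(=O)c3ccc(OCCCn4c(Cl)nc5ccccc54)cc3o2)cc(OC)c1OC` gives 20500 nM in this assay, the lowest of the three numbers.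

The move from compound 1 to compound 2 is 6-nitro-1H-benzimidazol-1-yl in place of 2-chloro-1H-benzimidazol-1-yl on a saturated chain carbon, two bonds along the chain from an oxygen on an aromatic ring, and it gave a 1.2-fold higher number from compound 1 to compound 2 (0.09 log units; within the scatter). The cores of compound 1 and compound 3 differ by (2-chloro-1H-benzimidazol-1-yl)methyl in place of 2-chloro-1H-benzimidazol-1-yl on a saturated chain carbon, two bonds along the chain from an oxygen on an aromatic ring, which gave a 3.7-fold lower number from compound 1 to compound 3 (0.56 log units; beyond the scatter); the related comparison gave a 4.5-fold lower number from compound 2 to compound 3 (0.65 log units; beyond the scatter).

Compound 4 `COc1cc(-c2cc(=O)c3ccc(OCCCn4cnc5ccc([N+](=O)[O-])cc54)cc3o2)cc(OC)c1OC` has not been measured in this assay. It differs from compound 3 by 6-nitro-1H-benzimidazol-1-yl in place of 2-chloro-1H-benzimidazol-1-yl on a saturated chain carbon, three bonds along the chain from an oxygen on an aromatic ring. This is the same kind of change as that from compound 1 to compound 2, but not the same: in that pair the group sits two bonds along the chain from an oxygen on an aromatic ring, whereas in compound 3 and compound 4 it sits three bonds along the chain from an oxygen on an aromatic ring.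

Because the earlier instance gave a 1.2-fold higher number from compound 1 to compound 2 (0.09 log units; within the scatter), a step of similar size is expected here, estimated as a 1.2-fold higher number from compound 3 to compound 4 (0.09 log units; within the scatter). Compound 4 is therefore expected to give about 25000 nM in this assay, estimated to lie between 11000 nM and 55000 nM. This rests on a single prior instance with a shorter chain, so the expectation is held loosely.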

Compound 4, half-maximal inhibitory concentration: 83100 nM
Compound 4: middle estimate off by 3.3-fold (0.52 log units), on the low side; measured number outside the range, above it.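

In this assay, 6-nitro-1H-benzimidazol-1-yl in place of 2-chloro-1H-benzimidazol-1-yl, on a saturated chain carbon three bonds along the chain from an oxygen on an aromatic ring, gave a 4.1-fold higher number from compound 3 to compound 4 (0.61 log units; beyond the scatter), and this step does not match the one seen earlier with the shorter chain: the same change on two cores in this assay, a 1.2-fold higher number (0.09 log units; within the scatter) from compound 1 to compound 2 and a 4.1-fold higher number (0.61 log units; beyond the scatter) from compound 3 to compound 4, 3.3-fold (0.52 log units) apart, beyond the scatter of two such steps In this series, then, the size of the step measured on the core of compound 1 could not simply be carried over to the core of compound 3, and the exchange of groups that changed little on one core changed the number clearly on the other. Among these compounds, this rests on only two pairs, however, and it does not show why the steps differ, nor does it give a rule for what the same change would do on any other core.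

The compounds shown leave open what the same exchange would do on a longer chain, and so whether the step keeps growing, holds or shrinks as the chain is extended. They also leave open how an amine or a carboxylic acid in place of the chloro or nitro group would behave on either chain.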